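The compounds below may be only part of what the source reports. "The series", "measured", "known", "first", "only" and "open" are said of these compounds alone.

Compound 2 `COc1cccc(C(=O)O[C@@H]2CO[C@H]3[C@@H]2OC[C@@H]3OC(=O)c2ccccc2OC(C)=O)c1` gives 0.0525 h in an ADME assay on a cell-free system (plasma, Homo sapiens) for metabolic stability, with Plasma (Rattus norvegicus) as the target, read by HPLC, at pH 7.4 (a lower number here means that the compound disappears faster, a higher number that the compound lasts longer), the lowest of the two numbers in hand; the nearest is compound 1 `CC(=O)Oc1ccccc1C(=O)O[C@H]1CO[C@H]2[C@@H]1OC[C@H]2OC(C)=O` with 0.0608 h, and the step of a 1.2-fold lower number from compound 1 to compound 2 (0.06 log units; within the scatter) stays within the scatter. Compound 3 `CC(=O)Oc1ccccc1C(=O)O[C@H]1CO[C@H]2[C@@H]1OC[C@H]2OC(=O)c1ccccc1CO[N+](=O)[O-]` carries the change (2-((nitrooxy)methyl)phenyl in place of 3-methoxyphenyl on a carbonyl carbon), on the same carbonyl carbon that varies between the two measured compounds. Within the data shown here, only that one measured step bears on the change, and it produced no shift beyond the scatter, so a move of similar size is expected, a 1.1-fold lower number from compound 2 to compound 3 (0.02 log units; within the scatter). Compound 3 is therefore estimated at 0.05 h, with a range from 0.025 h to 0.1 h.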

Compound 3, half-life: 0.045 h
Beside the measured number, compound 3's estimate is 1.1-fold (0.05 log units) above it; the measured number falls inside the stated range.
By their numbers in this assay, from the lowest: compounds 3, 2 and 1 (each within the scatter of the next).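

In this assay the larger 2-((nitrooxy)methyl)phenyl group on this carbonyl carbon gives a 1.2-fold lower number from compound 2 to compound 3 (0.07 log units; within the scatter) and a 1.4-fold lower number from compound 1 to compound 3 (0.13 log units; within the scatter) as its two steps, both within the scatter. Methyl, 3-methoxyphenyl and 2-((nitrooxy)methyl)phenyl at this position therefore give numbers that cannot be told apart, and no compound shown goes against this. Nothing measured here accounts for this flat result.

From the compounds shown here alone, whether a phenyl ring carrying an amine or a carboxylic acid on this carbonyl carbon would move the half-life beyond the scatter remains open. Changes elsewhere on the shared core also remain open.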